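Fluoro to methoxy on the aromatic ring of compound 1

The source may report more compounds than this note shows. Statements on the series, on what has been measured and on what is new or still open speak of the compounds shown alone.

compound 1 `O=C(CCCCCCc1ccc(F)cc1)N1CCCC1`: 8000 nM
compound 2 `O=C(CCc1ccc(-c2ccc(F)cc2)cc1)N1CCCC1`: 3400 nM
compound 3 `O=C(CCc1ccc(-c2cccc(Cl)c2)cc1)N1CCCC1`: 25400 nM

All three were measured in an assay on HEK293 cells for inhibition of N-acylethanolamine-hydrolyzing acid amidase (Rattus norvegicus), read by LC-MS, with a stated time of 30 min; on this read-out higher numbers stand for weaker inhibition and lower numbers for stronger inhibition. Compound 1 stands second highest of the three numbers; compound 2 sits at a lower number and compound 3 at a higher one, both beyond the scatter. Compound 4 `COc1ccc(CCCCCCC(=O)N2CCCC2)cc1` differs from compound 1 in a single way: methoxy in place of fluoro on an aromatic carbon. Among the measured compounds shown here, the only measured step that changes a group on the aromatic ring is a 7.5-fold higher number from compound 2 to compound 3 (0.87 log units; beyond the scatter), a modest move which shows that such a change can matter, though it points to no direction for this particular swap. The step from compound 1 to compound 4 is therefore expected to be small, a 1.1-fold lower number from compound 1 to compound 4 (0.06 log units; within the scatter), well within the scatter. Compound 4 is estimated at 7000 nM, within 2000 nM to 25000 nM.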

Compound 4, half-maximal inhibitory concentration: 35400 nM
The estimate for compound 4 lay 5.1-fold (0.70 log units) below the measured number, outside the stated range (above it).
By their numbers in this assay, from the lowest: compound 2; then compound 1; then compounds 3 and 4 (each within the scatter of the next).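

Methoxy in place of fluoro, para to a large group, gives a 4.4-fold higher number from compound 1 to compound 4 (0.65 log units; beyond the scatter) and so weakens inhibition on the core of compound 1. This position on the long-chain compounds therefore responds to what it carries, which the earlier step on the core of compound 2 could not show. Nothing available explains why the number rises with this swap.

As far as these compounds go, whether chloro, an amine or a carboxylic acid at this place would give a lower or higher number remains open. So does whether methoxy would have a similar effect on the core of compound 2.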